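Chloro next to the ring nitrogen: a repeated change

This account rests on a few compounds, and the source may have more. Where it says the series, first, only, none or still open, it means among the compounds named here.

Compound 1 `O=S(=O)(/C=C/c1ccccn1)c1ccc(F)cc1` and compound 3 `O=S(=O)(/C=C/c1ccccn1)c1cccc(Cl)c1` carry two different cores; the difference between the two cores is not broken down here. In an assay on U2OS cells for activation of nuclear factor erythroid 2-related factor 2 (Homo sapiens), read by beta-arrestin recruitment, with a stated time of 6 h (a lower number here means that less compound is needed, a higher number that more compound is needed for the effect), compound 1 gives 3100 nM, and compound 3 gives 1430 nM. Going by the values given here, compound 3 has the lowest of the three numbers so far, though against compound 2 the gap is within the scatter, and only against compound 1 does it lie beyond.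

Compound 2 `O=S(=O)(/C=C/c1cccc(Cl)n1)c1ccc(F)cc1` arises from compound 1 by chloro in place of hydrogen on an aromatic carbon. In this assay compound 2 gives 2790 nM, so the step is a 1.1-fold lower number from compound 1 to compound 2 (0.05 log units; within the scatter); this change left the number essentially where it was.

Compound 4 `O=S(=O)(/C=C/c1cccc(Cl)n1)c1cccc(Cl)c1` has not yet been measured. It arises from compound 3 by chloro in place of hydrogen on an aromatic carbon. The place of the change is described in the same words for both pairs, so the change from compound 3 to compound 4 is the same change that was already seen from compound 1 to compound 2.

Given that, the step is expected to be small, about a 1.1-fold lower number from compound 3 to compound 4 (0.04 log units; within the scatter). This expectation rests on the earlier, equivalent change, which gave a 1.1-fold lower number from compound 1 to compound 2 (0.05 log units; within the scatter), a step within the scatter. Among the compounds with values here, with only one prior example, the range is kept wide. For compound 4 the estimate in this assay is 1300 nM, with a likely span from 600 nM to 2800 nM.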

Compound 4, half-maximal effective concentration: 1070 nM
Estimate against measurement, compound 4: 1.2-fold (0.08 log units) above; the range from low to high includes it.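

On the core of compound 3, chloro in place of hydrogen on an aromatic carbon, next to the ring nitrogen, gives a 1.3-fold lower number from compound 3 to compound 4 (0.13 log units; within the scatter) in this assay. Set beside the earlier step, the change shows no detectable difference between the two cores: the same change on two cores in this assay, a 1.1-fold lower number (0.05 log units; within the scatter) from compound 1 to compound 2 and a 1.3-fold lower number (0.13 log units; within the scatter) from compound 3 to compound 4, 1.2-fold (0.08 log units) apart, within the scatter of two such steps. These two pairs show that, on these cores, the change leaves the number within the scatter of where it stood; they do not show that chloro at this place truly lowers the number, and they cannot say how the change would behave on any other core.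

Only hydrogen and chloro stand at this place in the compounds shown, so it remains open whether a methyl group, a methoxy group, an amine or a carboxylic acid there would move the number beyond the scatter. Also open, on these data alone, is whether the step stays this small on a core that carries a trifluoromethyl group or a nitrile in place of the fluoro of compound 1 or the core chloro of compound 3.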